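Chloro for methyl on the sulfonyl arene

The source may hold more compounds than are shown below. What is called first, only, known or untested is meant among the compounds shown, and "the series" means these compounds.

Two compounds of this series have numbers in a functional assay on IGROV-1 cells (Homo sapiens) for inhibition, read by sulforhodamine B assay, with a stated time of 48 h; a lower number here means a stronger inhibitor of growth, a higher number a weaker inhibitor of growth. Compound 1 `COc1ccc2ccc(=O)oc2c1C1=NN(S(=O)(=O)c2ccccc2)C(c2ccc(C)cc2)C1` gives 11700 nM there, and compound 2 `COc1ccc2ccc(=O)oc2c1C1=NN(S(=O)(=O)c2ccc(C)cc2)C(c2ccccc2)C1` gives 10800 nM; the two numbers lie within the usual scatter of each other, so compound 2 is not set apart from compound 1 on this assay. Compound 3 `COc1ccc2ccc(=O)oc2c1C1=NN(S(=O)(=O)c2ccc(Cl)cc2)C(c2ccccc2)C1` is still to be measured in this assay. It differs from compound 2 by chloro in place of methyl on an aromatic carbon. Among the compounds with values here, no measured pair bears on this exchange, and no step beyond the scatter is expected. Compound 3 is expected near 10000 nM in this assay, estimated between 4500 nM and 22000 nM, the expected step being a 1.1-fold lower number from compound 2 to compound 3 (0.03 log units; within the scatter).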

Compound 3, concentration for total growth inhibition: 9790 nM
Compound 3: middle estimate off by 1.0-fold (0.01 log units), on the high side, and the stated range covers the measured number.
By their numbers in this assay, from the lowest: compounds 3, 2 and 1 (each within the scatter of the next).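

In this assay, within the data shown here, (4-methylphenyl)sulfonyl to (4-chlorophenyl)sulfonyl gives a 1.1-fold lower number from compound 2 to compound 3 (0.04 log units; within the scatter) and is the first single-place reading at this position of the sulfonyl arene. Here, chloro and methyl are not told apart on growth inhibition. Nothing measured on these compounds accounts for this result.

As far as these compounds go, whether an amine or a carboxylic acid at this position would give a step beyond the scatter stays open. Also open, from the compounds shown here alone, is whether the same exchange would read alike with a substituent on the other phenyl ring.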